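Aziridinylquinones: Swapping a Carbamate Side Chain for Phenyl

This account rests on a few compounds, and the source may have more. Where it says the series, first, only, none or still open, it means among the compounds named here.

Of the compounds shown here, three sharing one core have been measured in a functional assay on L1210 cells (Mus musculus), with a stated time of 1 days; on this read-out higher numbers stand for higher potency (the scale is a negative logarithm) and lower numbers for lower potency. Compound 1 `CCCC1=C(N2CC2)C(=O)C(C(COC(N)=O)OC)=C(N2CC2)C1=O` gives 4.64, compound 2 `CC1=C(N2CC2)C(=O)C(CC(C)OC(N)=O)=C(N2CC2)C1=O` gives 5.18, and compound 3 `O=C1C(CCO)=C(N2CC2)C(=O)C(CCO)=C1N1CC1` gives 5.6. Compound 2 thus stands second of the three: compound 3 is higher and compound 1 lower, both by more than the usual scatter.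

Compound 4 `CC1=C(N2CC2)C(=O)C(Cc2ccccc2)=C(N2CC2)C1=O` differs from compound 2 by a group of 6 heavy atoms (6 carbon; one six-membered aromatic ring of carbon only) in place of a group of 6 heavy atoms (3 carbon, 1 nitrogen, 2 oxygen; no ring), on a saturated chain carbon bound to a double-bonded ring carbon. Going by the values given here, no pair of measured compounds shows this kind of change, so its effect is not known here. With compound 2 at 5.18 as the starting point, the step from compound 2 to compound 4 is expected to be a number 0.18 log units lower from compound 2 to compound 4 (within the scatter), a small lowering that may not exceed the scatter. Compound 4 is therefore estimated at 5, within 4.4 to 5.6.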

Compound 4, logarithm of the reciprocal of the active concentration, log(1/C): 4.26
Estimate against measurement, compound 4: 0.74 log units above; measured number below the stated range.
By their numbers in this assay, from the lowest: compound 4; then compound 1; then compound 2; then compound 3.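

In this assay, phenyl in place of the open-chain group on this saturated chain carbon gives a number 0.92 log units lower from compound 2 to compound 4 (beyond the scatter). Going by these compounds alone, this is the first comparison here that changes one place only, and it shows that this position responds to what it carries, even though both groups have 6 heavy atoms. Nothing here explains the drop. The compounds shown leave open whether the aromatic ring or the loss of the hydrogen-bond donor and acceptors matters more. A cyclohexyl group or an amine at this place could help separate the two.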